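Series notes: nitro replacing methyl, compound 3 to compound 4

The source may hold more compounds than are shown below. What is called first, only, known or untested is meant among the compounds shown, and "the series" means these compounds.

Measured compounds:
compound 1, `COc1ccc(OCC(=O)N2CCN(c3ccc(C(F)(F)F)cc3[C@@H](N)CC(C)C)CC2)cc1`, gives 3800 nM in an assay on HEK293 cells for displacement of a labelled ligand from Melanocortin receptor 4 (Homo sapiens); on this read-out lower numbers stand for stronger inhibition and higher numbers for weaker inhibition
compound 2, `CC(C)C[C@H](N)c1cc(C(F)(F)F)ccc1N1CCN(C(=O)CCNC2CCCCC2)CC1`, gives 4800 nM in this assay
compound 3, `Cc1ccc(OCC(=O)N2CCN(c3ccc(C(F)(F)F)cc3[C@@H](N)CC(C)C)CC2)cc1`, gives 4400 nM in this assay

The three compounds share one core and differ only in the group carried on the saturated chain carbon bound to the carbonyl carbon. In this assay compound 3 stands second highest of the three numbers; a 1.1-fold lower number from compound 2 to compound 3 (0.04 log units; within the scatter) and a 1.2-fold higher number from compound 1 to compound 3 (0.06 log units; within the scatter) both fall within the scatter, so the three are indistinguishable on these data.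

Compound 4, `CC(C)C[C@H](N)c1cc(C(F)(F)F)ccc1N1CCN(C(=O)COc2ccc([N+](=O)[O-])cc2)CC1`, is not yet measured. nitro in place of methyl on an aromatic carbon The change sits on the same aromatic carbon as the change measured by a 1.2-fold higher number from compound 1 to compound 3 (0.06 log units; within the scatter), and the larger swap of the whole side group, a 1.3-fold higher number from compound 1 to compound 2 (0.10 log units; within the scatter), also stayed within the scatter. Among the compounds with values here, no measured step involves a nitro group, so the present steps are the only guide. On that basis no step beyond the scatter is expected in this assay for compound 4; the expected step is no change at the digits printed from compound 3 to compound 4 (within the scatter). Compound 4 is estimated at 4400 nM, with a range from 1800 nM to 11000 nM.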

Compound 4, inhibition constant: 3100 nM
Beside the measured number, compound 4's estimate is 1.4-fold (0.15 log units) above it, within the range that was stated.
By their numbers in this assay, from the lowest: compounds 4, 1, 3 and 2 (each within the scatter of the next).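

Working notes: the aromatic carbon para to a large group now carries a third group in this assay, and neither nitro in place of methyl (a 1.4-fold lower number from compound 3 to compound 4 (0.15 log units; within the scatter)) nor nitro in place of methoxy (a 1.2-fold lower number from compound 1 to compound 4 (0.09 log units; within the scatter)) leaves the scatter. The swap of the whole side group, 4-nitrophenoxy in place of (cyclohexylamino)methyl (a 1.5-fold lower number from compound 2 to compound 4 (0.19 log units; within the scatter)), also stays within the scatter, so compound 4 adds a nitro group to the set without separating any of the four compounds. No measurement here bears on why this position tolerates the change.

On these data alone, whether an amine or a carboxylic acid on that aromatic carbon would give a step beyond the scatter remains open. Also open, as far as these compounds go, is what a longer chain in place of (4-nitrophenoxy)methyl, or any change to the shared core, would do in this assay.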